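Swapping Cyclobutyl for Oxan-2-yl on the Amide Carbonyl

This account rests on a few compounds, and the source may have more. Where it says the series, first, only, none or still open, it means among the compounds named here.

Measured compounds in an assay on HEK293 cells for negative allosteric modulation of metabotropic glutamate receptor 5 (Homo sapiens), read by FLIPR, with a stated time of 1 h; a higher number here means a weaker inhibitor, a lower number a stronger inhibitor:
Compound 1, `COc1ccccc1C#Cc1nc2c(s1)C(=O)NCC2`, gives only a limit of the assay, > 10000 nM.
Compound 2, `Cc1cccc(C#Cc2nc3c(s2)C(=O)NCC3)c1`, also gives only a limit of the assay, > 10000 nM.
Compound 3, `O=C(C1CCC1)N1CCc2nc(C#Cc3ccccc3)sc2C1`, gives 370 nM.

Within the data shown here, compound 3 is thus the only compound of the three with a real number in this assay; the other two sit at the limit of > 10000 nM in this assay, at which 2 of the 3 values shown sit, so nothing can be said about how far they lie from compound 3. Among the measured compounds shown here, no pair of measured compounds differs in a single place, so the measured set gives no step from which the size of a small change at the amide could be read.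

Compound 4, `O=C(C1CCCCO1)N1CCc2nc(C#Cc3ccccc3)sc2C1`, differs from compound 3 in one place: oxan-2-yl in place of cyclobutyl on a carbonyl carbon. For the measured compounds named here, with no measured step to lean on, the step of a 1.5-fold higher number from compound 3 to compound 4 (0.17 log units; within the scatter) is expected to be small, within or only slightly beyond the usual scatter, if anything toward weaker inhibition. Compound 4 is therefore estimated at 550 nM, with a likely range from 150 nM to 2500 nM.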

Compound 4, half-maximal inhibitory concentration: > 10000 nM
Compound 4 gave a limit, no number (the forecaster's own chance of this, stated with the estimate: 10%); middle value at least 18-fold (1.25 log units) away from the limit.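

In this assay, oxan-2-yl in place of cyclobutyl on the carbonyl carbon gives an at least 27-fold higher number from compound 3 to compound 4 (1.43 log units; beyond the scatter), a large step and the first one in this set that can be read. This position therefore does not accept every ring: changing a four-membered carbon ring to a six-membered ring holding an oxygen takes the compound from a real number to a limit of the assay. Compound 4 gives only a limit, so the step is a minimum and its true size stays unknown: the limit of > 10000 nM in this assay, at which 3 of the 4 values shown sit.

The compounds shown do not separate ring size from the ring oxygen: cyclohexyl on the same carbonyl carbon would carry the six-membered ring without the oxygen, and oxetan-2-yl would carry the oxygen in a four-membered ring. From the compounds shown here alone, whether an open chain such as isopropyl is accepted here also remains open.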